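The source may hold more compounds than are shown below. What is called first, only, known or untested is meant among the compounds shown, and "the series" means these compounds.

Among the compounds with values here, compound 2 `COc1ccc(C(=O)/C=C/c2ccc(N(C)C)cc2)c2c1C=CC(C)(C)O2` carries a dimethylamino group and in a functional assay on HT-29 cells (Homo sapiens) for antiproliferative activity, read by MTT assay, with a stated time of 24 h (on this read-out lower numbers stand for stronger inhibition and higher numbers for weaker inhibition), gives 1870 nM, the only plain number among the compounds. Compound 1 `COc1ccc(C(=O)/C=C/c2ccc(Br)cc2)c2c1C=CC(C)(C)O2` gives in this assay > 10000 nM, which is a limit of the assay (the limit of > 10000 nM in this assay, at which 1 of the 2 values shown sits). Within the data shown here, the one measured step, an at least 5.3-fold lower number from compound 1 to compound 2 (0.72 log units; beyond the scatter), replaced a bromo with the dimethylamino. Compound 3 `COc1ccc(C(=O)/C=C/c2ccc(-c3ccccc3)cc2)c2c1C=CC(C)(C)O2` brings (phenyl in place of dimethylamino on an aromatic carbon). Among the measured compounds shown here, no measured step covers this change directly; since the step of an at least 5.3-fold lower number from compound 1 to compound 2 (0.72 log units; beyond the scatter) shows the dimethylamino accompanying the lower number, removing it is expected to raise the number beyond the scatter. Compound 3 is therefore estimated at 5500 nM, between 1800 nM and 20000 nM, meaning a 2.9-fold higher number from compound 2 to compound 3 (0.47 log units; beyond the scatter).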

Compound 3, half-maximal inhibitory concentration: > 10000 nM
Compound 3: no number, only a limit (the forecaster's own chance of this, stated with the estimate: 35%); middle value at least 1.8-fold (0.25 log units) from the limit.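

Replacing the dimethylamino with phenyl on this aromatic carbon gives an at least 5.3-fold higher number from compound 2 to compound 3 (0.72 log units; beyond the scatter), so the ring brought in by phenyl does not keep the activity seen with dimethylamino. Of the three groups shown at this position, only dimethylamino gives a plain number, while phenyl and bromo both stand at a limit of the assay: the limit of > 10000 nM in this assay, at which 2 of the 3 values shown sit. The two limits leave the step between compound 1 and compound 3 unreadable. The compounds shown leave open whether another amine, such as a primary amino group or a piperidine, would also give a plain number here.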